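Ortho Halogen on the Triazole Phenyl: From Chloro to Iodo

The source may hold more compounds than are shown below. What is called first, only, known or untested is meant among the compounds shown, and "the series" means these compounds.

Compound 1 `O=C(Nc1cccc(OCc2cn(-c3ccccc3)nn2)c1)Nc1ccc(Cl)c(C(F)(F)F)c1`: 1780 nM
Compound 2 `O=C(Nc1cccc(OCc2cn(-c3ccccc3Cl)nn2)c1)Nc1ccc(Cl)c(C(F)(F)F)c1`: 1960 nM

In a functional assay on HepG2 cells (Homo sapiens) for inhibition, read by MTT assay, with a stated time of 72 h (a lower number here means a stronger inhibitor, a higher number a weaker inhibitor), compound 1 gives 1780 nM, the lowest of the two numbers shown. Its nearest neighbour is compound 2, which in this assay gives 1960 nM; the step of a 1.1-fold higher number from compound 1 to compound 2 (0.04 log units; within the scatter) is within the scatter, so the two compounds cannot be told apart on these numbers.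

Compound 3 `O=C(Nc1cccc(OCc2cn(-c3ccccc3I)nn2)c1)Nc1ccc(Cl)c(C(F)(F)F)c1` has not yet been measured. It differs from compound 1 by iodo in place of hydrogen on an aromatic carbon. Among the compounds with values here, the one measured step that bears on this change is the step from compound 1 to compound 2, where chloro entered at the same place on the same ring and gave a 1.1-fold higher number from compound 1 to compound 2 (0.04 log units; within the scatter). Iodo is a heavier halogen than chloro, but no measured step shows what that brings here.

On this basis compound 3 is expected to give a number close to that of compound 1, with a step of a 1.1-fold higher number from compound 1 to compound 3 (0.03 log units; within the scatter) that does not clearly exceed the scatter. The estimate for compound 3 in this assay is 1900 nM, with a range from 900 nM to 4000 nM.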

Compound 3, half-maximal inhibitory concentration: 2870 nM
Beside the measured number, compound 3's estimate is 1.5-fold (0.18 log units) below it; the measured number falls inside the stated range.
By their numbers in this assay, from the lowest: compounds 1, 2 and 3 (each within the scatter of the next).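

In this assay, placing iodo on the aromatic carbon ortho to a large group gives a 1.6-fold higher number from compound 1 to compound 3 (0.21 log units; within the scatter), so this single heavy atom, like chloro before it, produces a step that stays inside the scatter. Exchanging one halogen for the other at this carbon gives a 1.5-fold higher number from compound 2 to compound 3 (0.17 log units; within the scatter), which extends the earlier finding from one pair to three compounds that cannot be told apart, with hydrogen, chloro and iodo all giving numbers within the scatter of one another on this ring. No measurement at hand offers an explanation for these numbers, and the reading therefore stays with the numbers alone.

What the compounds shown leave open is whether any group at this carbon can move the number beyond the scatter, since a group such as an amine, a carboxylic acid or a longer chain does not appear among them. They also leave open whether iodo or chloro would give a similar result on the other carbons of this ring, and whether the same holds on the core of compound 1 with other substituents.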